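Compound 3: a sulfanyl group replaces the amino chain

This account rests on a few compounds, and the source may have more. Where it says the series, first, only, none or still open, it means among the compounds named here.

Compound 2 `CCCN(CCN(C)C)c1nc(CC)c(-c2ccc(Cl)cc2Cl)nc1CC` is the reference point in an in vitro ADME assay on microsomes (Rattus norvegicus) for metabolic stability; a higher number here means that the compound lasts longer, a lower number that the compound disappears faster. Compound 2 gives < 0.0167 h, which is a limit of the assay and not a number. Compound 1 `CCc1nc(-c2ccc(Cl)cc2Cl)c(CC)nc1NC(C)CN(C)C` gives < 0.0167 h, which is likewise a limit.

Compound 3 `CCc1nc(-c2ccc(Cl)cc2Cl)c(CC)nc1SC(C)CC` has not yet been measured. Here (sec-butyl)sulfanyl stands in place of (2-(dimethylamino)ethyl)(propyl)amino, para to a 2,4-dichlorophenyl group: (sec-butyl)sulfanyl in place of (2-(dimethylamino)ethyl)(propyl)amino on an aromatic carbon.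

For the measured compounds named here, the one measured step, a step that the two limits leave unreadable from compound 1 to compound 2, offers no size to carry over. The evidence amounts to this: the limit of < 0.0167 h in this assay, at which 2 of the 2 values shown sit. With so little to go on, no change beyond the usual scatter is expected in this assay, and no direction can be favoured. The expected step is an at least 1.1-fold higher number from compound 2 to compound 3 (0.07 log units; that floor lies within the scatter). For compound 3 the estimated half-life is 0.02 h, with an expected range from 0.01 h to 0.06 h.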

Compound 3, half-life: 0.0683 h
Compound 3: the middle estimate sits 3.4-fold (0.53 log units) below what was measured; measured number above the stated range.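

In this assay, the group on this aromatic carbon can shift the read-out: (sec-butyl)sulfanyl in place of (2-(dimethylamino)ethyl)(propyl)amino gives an at least 4.0-fold higher number from compound 2 to compound 3 (0.61 log units; beyond the scatter). The same group in place of (1-((dimethylamino)methyl)ethyl)amino gives an at least 4.0-fold higher number from compound 1 to compound 3 (0.61 log units; beyond the scatter), so both amino chains lead to the same reading, while the step between those two amino compounds cannot be read. Each of the new steps is only a floor, because neither amino compound gives a number: the limit of < 0.0167 h in this assay, at which 2 of the 3 values shown sit.

The change swaps the nitrogen link for sulfur and removes the dimethylamino group at once, so the compounds shown do not tell which of the two goes with the higher number. A sec-butylamino group, or a sulfanyl group carrying a 2-(dimethylamino)ethyl chain, would separate them.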